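This account rests on a few compounds, and the source may have more. Where it says the series, first, only, none or still open, it means among the compounds named here.

Compound 2 `CNC(=O)c1ccc(N2CC(=O)N(c3ccc(C#N)c(C(F)(F)F)c3)C2=S)cc1F` gives > 10000 nM in a functional assay on LNCaP cells (Homo sapiens) for antiproliferative activity, with a stated time of 3 days (on this read-out higher numbers stand for weaker inhibition and lower numbers for stronger inhibition), and this is a limit of the assay, not a number. Its closest measured neighbour, compound 1 `CNC(=O)c1ccc(N2C(=S)N(c3ccc(C#N)c(C(F)(F)F)c3)C(=O)[C@@H]2C)cc1F`, gives 398 nM in this assay. Among the compounds with values here, the one measured step between them is an at least 25-fold higher number from compound 1 to compound 2 (1.40 log units; beyond the scatter), which is large and comes from losing a single methyl. Compound 3 `CNC(=O)c1ccc(N2C(=S)N(c3ccc(C#N)c(C(F)(F)F)c3)C(=O)[C@H]2C)cc1F` restores that group, with methyl in place of hydrogen on a saturated ring carbon. However, compound 3 is the mirror image of compound 1, so it need not recover all of the potency. Within the data shown here, compound 1, at 398 nM, is the only guide, and it suggests a move towards stronger inhibition, probably a smaller one than the measured step. The expected change is an at least 5.0-fold lower number from compound 2 to compound 3 (0.69 log units; beyond the scatter). For compound 3 the estimated value is 2000 nM, with an expected range of 350 nM to 10000 nM.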

Compound 3, half-maximal inhibitory concentration: 1510 nM
Compound 3: middle estimate off by 1.3-fold (0.12 log units), on the high side, and the stated range covers the measured number.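

In this assay, methyl on this saturated ring carbon helps in both drawn configurations, not only in that of compound 1: the change gives an at least 6.6-fold lower number from compound 2 to compound 3 (0.82 log units; beyond the scatter). The configuration still matters, with a 3.8-fold higher number from compound 1 to compound 3 (0.58 log units; beyond the scatter), and this gap can only come from the arrangement in space: the fact that compounds 1 and 3 differ only in the configuration as drawn. Compound 2 gives a limit of the assay and not a number, so the gain from methyl has only a lower bound: the limit of > 10000 nM in this assay, at which 1 of the 3 values shown sits.

From the compounds shown here alone, whether an ethyl group, a longer chain or a hydroxymethyl group on this ring carbon would do better than methyl, in either configuration, stays open. Nor do the compounds shown tell whether two methyl groups on that same carbon, which would leave no stereocentre there, would match compound 1.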